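The source may hold more compounds than are shown below. What is called first, only, known or untested is meant among the compounds shown, and "the series" means these compounds.

Series notes. Compound 1 `O=C(NC1CCN(Cc2ccc(OC3CCNCC3)c(Br)c2)CC1)c1ccccn1` gives 120 nM in an assay on HEK293 cells for displacement of a labelled ligand from Urotensin-2 receptor (Homo sapiens), read by fluorescence, with a stated time of 90 min; a higher number here means a weaker inhibitor, a lower number a stronger inhibitor. Compound 2 `N#Cc1ccc2cc(C(=O)NC3CCN(Cc4ccc(OC5CCNCC5)c(Br)c4)CC3)sc2c1` gives 80 nM in this assay. Among the compounds with values here, the one step measured so far, a 1.5-fold lower number from compound 1 to compound 2 (0.18 log units; within the scatter), exchanges the whole group on the carbonyl carbon and lands within the scatter. Compound 2 therefore carries the lower of the two numbers recorded, but its gap to compound 1 is within the scatter, so no order between the two is read from it.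

Compound 3 `COc1ccc2sc(C(=O)NC3CCN(Cc4ccc(OC5CCNCC5)c(Br)c4)CC3)cc2c1` is not yet measured. Its change from compound 2: 5-methoxy-1-benzothiophen-2-yl in place of 6-cyano-1-benzothiophen-2-yl on a carbonyl carbon. Within the data shown here, the only step that bears on it is the exchange on the same carbonyl carbon, a 1.5-fold lower number from compound 1 to compound 2 (0.18 log units; within the scatter), which swapped in an unrelated group and still stayed within the scatter. The present change keeps the two-ring group and trades one substituent for another, so on this basis no step beyond the scatter is expected in this assay. For compound 3 the expected step is a 1.3-fold higher number from compound 2 to compound 3 (0.10 log units; within the scatter). Compound 3 is estimated at 100 nM, with a range from 40 nM to 250 nM.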

Compound 3, half-maximal inhibitory concentration: 100 nM
The estimate for compound 3 equals the measured number at the digits printed, and the stated range covers the measured number.
By their numbers in this assay, from the lowest: compounds 2, 3 and 1 (each within the scatter of the next).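

In this assay, replacing 6-cyano-1-benzothiophen-2-yl with 5-methoxy-1-benzothiophen-2-yl on the carbonyl carbon stays within the scatter (a 1.3-fold higher number from compound 2 to compound 3 (0.10 log units; within the scatter)), so this place now has two differently substituted 1-benzothiophen-2-yl groups with no order between them. The second new step, from the pyridin-2-yl group, is also within the scatter (a 1.2-fold lower number from compound 1 to compound 3 (0.08 log units; within the scatter)), which means that all three groups on this carbonyl carbon give numbers that cannot be ranked, and the earlier exchange is no longer a lone observation. No supporting measurement bears on this result.

In the step between the two 1-benzothiophen-2-yl groups, both the substituent and its numbered place change at once, so their separate contributions remain unresolved. Within the data shown here, also open is whether an amine or a carboxylic acid on the 1-benzothiophen-2-yl group, or the same group with no substituent, would stay within the scatter or produce the first step beyond it at this place.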